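The source may hold more compounds than are shown below. What is called first, only, known or untested is meant among the compounds shown, and "the series" means these compounds.

Measured compounds:
compound 1 `CCC/C=C/C(=O)Nc1cc2c(N3CCc4ccccc43)ncnc2cc1O[C@@H]1CCOC1`: 4550 nM
compound 2 `C/C=C/C(=O)Nc1cc2c(N3CCCc4ccccc43)ncnc2cc1OC`: 12700 nM
compound 3 `C/C=C/C(=O)Nc1cc2c(N3CCCc4ccccc43)ncnc2cc1O[C@@H]1CCOC1`: 5930 nM

In a functional assay on MCF7 cells (Homo sapiens) for antiproliferative activity, read by MTT assay, with a stated time of 72 h (a higher number here means a weaker inhibitor, a lower number a stronger inhibitor), compound 2 gives the highest of the three numbers. Compound 3 lies nearest, and the step of a 2.1-fold lower number from compound 2 to compound 3 (0.33 log units; beyond the scatter) is modest, while compound 1 gives the lowest number of the three. Compound 4 `COc1cc2ncnc(N3CCCc4ccccc43)c2cc1NC(=O)/C=C/CN1CCCCC1` differs from compound 2 by piperidin-1-yl in place of hydrogen on a saturated chain carbon bound to a double-bonded chain carbon. No measured step touches this place: the one step shown changes the group on the oxygen on the aromatic ring, not the chain of the amide, so there is nothing to scale from. The expectation is therefore a step in this assay no larger than the one shown, with the direction uncertain, and the estimated step is a 1.6-fold lower number from compound 2 to compound 4 (0.20 log units; within the scatter). Compound 4 is estimated at 8000 nM, within 2500 nM to 25000 nM.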

Compound 4, half-maximal inhibitory concentration: 3930 nM
Compound 4: middle estimate off by 2.0-fold (0.31 log units), on the high side, and the stated range covers the measured number.
By their numbers in this assay, from the lowest: compounds 4, 1 and 3 (each within the scatter of the next); then compound 2.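

In this assay, the chain of the amide proves able to move the number: piperidin-1-yl on a saturated chain carbon bound to a double-bonded chain carbon gives a 3.2-fold lower number from compound 2 to compound 4 (0.51 log units; beyond the scatter). This place, untouched by the earlier change on the oxygen, therefore accepts a six-membered non-aromatic ring containing nitrogen without loss of activity. Nothing available explains the drop in the number. From the compounds shown here alone, whether the whole ring matters or only its nitrogen stays open; dimethylamino or morpholin-4-yl on the same carbon would help separate the two.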